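The source may hold more compounds than are shown below. What is called first, only, known or untested is meant among the compounds shown, and "the series" means these compounds.

Measured compounds:
- compound 1 `CC(C)=CCc1cc(-c2oc3c(CC=C(C)C)c(O)cc(O)c3c(=O)c2O)ccc1O`: 9700 nM
- compound 2 `CC(C)=CCC/C(C)=C/Cc1c(-c2ccc(O)cc2O)oc2cc(O)cc(O)c2c1=O`: 24000 nM

Two compounds of the series have been run in an assay for inhibition of Aromatase (Homo sapiens), using microsomes; on this read-out lower numbers stand for stronger inhibition and higher numbers for weaker inhibition. Compound 1 gives 9700 nM and holds the lowest of the two numbers. Compound 2 gives 24000 nM, a higher number than compound 1 by a margin that lies beyond the usual scatter. Among the measured compounds shown here, no pair of these two compounds differs in only one place, so no single-point step between measured compounds is available.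

Compound 3 `CC(C)=CCc1cc(-c2oc3cc(O)cc(O)c3c(=O)c2O)ccc1O` is the next compound to be measured in this assay. It differs from compound 1 by hydrogen in place of 3-methylbut-2-en-1-yl on an aromatic carbon; in words, hydrogen in place of 3-methylbut-2-en-1-yl on an aromatic carbon. For the measured compounds named here, no measured pair shows what this change does here. Taking compound 1 at 9700 nM as the only anchor, the step from compound 1 to compound 3 is expected to be modest and to run toward a higher number, plausibly beyond the scatter but not far, giving an expected 2.1-fold higher number from compound 1 to compound 3 (0.31 log units; beyond the scatter). For compound 3 the estimate in this assay is 20000 nM, with a range from 7000 nM to 60000 nM.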

Compound 3, half-maximal inhibitory concentration: 100 nM
The estimate for compound 3 lay 200-fold (2.30 log units) above the measured number; measured number below the stated range.
By their numbers in this assay, from the lowest: compound 3; then compound 1; then compound 2.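

Hydrogen in place of 3-methylbut-2-en-1-yl on this aromatic carbon, ortho to a hydroxy group and para to a hydroxy group, gives a 97-fold lower number from compound 1 to compound 3 (1.99 log units; beyond the scatter) in this assay. The position is therefore far from indifferent: a single change here moves the number by a large margin, and in this pair the unsubstituted carbon goes with the stronger inhibition, while the 3-methylbut-2-en-1-yl group elsewhere on the shared core is present in both compounds. Nothing at hand accounts for the size of this step.

With only hydrogen and 3-methylbut-2-en-1-yl compared on this carbon, the compounds shown leave open whether any group here goes with weaker inhibition or only one of this size and shape, as a methyl, a methoxy or a longer chain such as geranyl would help to tell. They also leave open what the remaining 3-methylbut-2-en-1-yl group of compound 3 contributes, and whether this step would hold on a different core.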